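The source may report more compounds than this note shows. Statements on the series, on what has been measured and on what is new or still open speak of the compounds shown alone.

Compound 1 `COc1cc(-c2cc(/C=C/C(=O)c3ccc(N)cc3)[nH]n2)cc(OC)c1OC` was examined in a functional assay on NCI-H23 cells (Homo sapiens) for cytotoxicity, read by sulforhodamine B assay, with a stated time of 48 h, tested at 10 uM (a higher number here means a weaker effect of the compound at the concentration tested, a lower number a stronger effect), where compound 1 gives -19%. Among the three compounds measured, this places compound 1 second highest. Compound 2 `COc1ccc(-c2cc(/C=C/C(=O)c3ccc(OC)c(OC)c3)[nH]n2)cc1` gives -24%, a value within the scatter of compound 1, so the two show no difference that can be read. Going by the values given here, compound 3 `COc1cc(-c2cc(/C=C/C(=O)c3ccc(Cl)c(Cl)c3)[nH]n2)cc(OC)c1OC` gives 79%, and the one measured step with a single change, a number 98 percentage points higher from compound 1 to compound 3 (beyond the scatter), is large and lies beyond the scatter.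

Compound 4 `COc1ccc(-c2cc(/C=C/C(=O)c3ccc(N)cc3)[nH]n2)cc1OC` is the next step from compound 1. The change is hydrogen in place of methoxy on an aromatic carbon, on the ring that carries the methoxy groups, not on the carbonyl-bearing ring. Among the compounds with values here, the only step measured so far, from compound 1 to compound 3, concerns the other ring, so no measured step bears directly on this change. With nothing to point either way, a step of no more than the scatter is expected, a number 4 percentage points higher from compound 1 to compound 4 (within the scatter). Compound 4 is therefore estimated at -15%, with a range from -45% to 15%.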

Compound 4, a percentage reported as activity, at one concentration (the size of the read-out at that concentration, not a potency): 21%
Beside the measured number, compound 4's estimate is 36 percentage points below it; measured number above the stated range.
By their numbers in this assay, from the lowest: compounds 2 and 1 (each within the scatter of the next); then compound 4; then compound 3.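

Hydrogen in place of methoxy, on an aromatic carbon ortho to a methoxy group and meta to a large group, brings a number 40 percentage points higher from compound 1 to compound 4 (beyond the scatter) in this assay. The change therefore moves the read-out toward a weaker effect at the concentration tested, which shows that this ring also matters and not only the group on the carbonyl carbon, since the 4-aminophenyl group stays the same across this step. No measurement at hand accounts for the size of this step.

From the compounds shown here alone, whether another group at this place, such as hydroxyl, fluorine or ethoxy, would stand nearer to compound 1 or to compound 4 remains open. So does whether the loss of this methoxy group would count the same with 3,4-dichlorophenyl on the carbonyl carbon.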